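Returning an Aryl Ring to the Amine Nitrogen

A few compounds are considered here, and "the series" means these few. Any claim that something is new, unique, unknown or untested is made for them only; others in the source may bear on it.

Three compounds share one core and differ only in the group carried on the ring amine nitrogen. Compound 1 `CCCn1c(=O)[nH]c2nc(-c3ccc(S(=O)(=O)N4CCN(c5ccccc5C)CC4)cc3)[nH]c2c1=O` carries 2-methylphenyl there and gives 419 nM in an assay on CHO cells for displacement of a labelled ligand from adenosine receptor A1 (Homo sapiens), read by scintillation counting, with a stated time of 90 min, in the presence of a further agent that is not named here; a lower number here means a stronger inhibitor, a higher number a weaker inhibitor. Compound 2 `CCCn1c(=O)[nH]c2nc(-c3ccc(S(=O)(=O)N4CCN(Cc5cccc(Br)c5)CC4)cc3)[nH]c2c1=O` carries 3-bromobenzyl and gives 928 nM in this assay. Compound 3 `CCCn1c(=O)[nH]c2nc(-c3ccc(S(=O)(=O)N4CCN(C(C)c5ccccc5)CC4)cc3)[nH]c2c1=O` carries 1-phenylethyl. In this assay the result for compound 3 is a limit rather than a number, >= 1000 nM (the limit of >= 1000 nM in this assay, at which 1 of the 3 values shown sits). Among the measured steps, a 2.2-fold higher number from compound 1 to compound 2 (0.35 log units; beyond the scatter) and an at least 2.3-fold higher number from compound 1 to compound 3 (0.37 log units; beyond the scatter) both moved away from compound 1 toward weaker inhibition, while an at least 1.0-fold higher number from compound 2 to compound 3 (0.03 log units; that floor lies within the scatter) shows no difference that can be trusted.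

Compound 4 `CCCn1c(=O)[nH]c2nc(-c3ccc(S(=O)(=O)N4CCN(c5ccccc5Cl)CC4)cc3)[nH]c2c1=O` carries 2-chlorophenyl in place of 1-phenylethyl on an amine nitrogen in a ring. This change puts an aromatic ring directly on the nitrogen again, as in compound 1, and the step of an at least 2.3-fold higher number from compound 1 to compound 3 (0.37 log units; beyond the scatter) shows that leaving that arrangement for 1-phenylethyl raised the number. Reversing it is therefore expected to lower the number, with an expected step of an at least 2.0-fold lower number from compound 3 to compound 4 (0.30 log units; that floor lies within the scatter) in this assay. Compound 4 is expected to give about 500 nM in this assay, within an estimated range of 200 nM to 1500 nM.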

Compound 4, inhibition constant: > 1000 nM
Compound 4 gave a limit, no number; the forecaster's own chance of this, stated with the estimate: 15%; at least 2.0-fold (0.30 log units) between middle value and limit.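

The result for compound 4 in this assay is a limit and not a number: the limit of > 1000 nM in this assay, at which 1 of the 4 values shown sits. Compound 3 also gave a limit, and the step between these two compounds cannot be read, so this swap of 1-phenylethyl for 2-chlorophenyl gives no measured size. What compound 4 adds is that an aromatic ring placed directly on the amine nitrogen does not by itself keep the number near that of compound 1: chloro in place of methyl on that ring gives an at least 2.3-fold higher number from compound 1 to compound 4 (0.37 log units; beyond the scatter), while the comparison with the 3-bromobenzyl compound gives only an at least 1.0-fold higher number from compound 2 to compound 4 (0.03 log units; that floor lies within the scatter) and so shows no difference that can be trusted.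

The group on the aromatic ring therefore matters here as much as the ring's attachment to the nitrogen, at least for this one pair of compounds. Still open, going by these compounds, is whether a plain phenyl, or a methoxy or a nitrile in place of the chloro, would give a readable number in this assay and how such a number would compare with compound 1.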